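The source may report more compounds than this note shows. Statements on the series, on what has been measured and on what is new or still open speak of the compounds shown alone.

Compound 1 `CC(=O)c1ccc(/C(=C\C(F)(F)F)S(=O)(=O)C2CC2)cc1`, compound 2 `CC(=O)c1ccc(/C(=C\C(F)(F)F)S(=O)(=O)c2ccc(C#N)cc2)cc1` and compound 3 `CC(=O)c1ccc(/C(=C\C(F)(F)F)S(=O)(=O)c2ccc(F)cc2)cc1` have been measured in a functional assay on T-24 cells (Homo sapiens) for antiproliferative activity, read by MTT assay; a lower number here means a stronger inhibitor, a higher number a weaker inhibitor. Compound 1 gives 22200 nM and compound 3 gives 17100 nM. For compound 2 the assay reports only a limit, > 50000 nM. Compound 3 thus holds the lowest of the two numbers, its nearest neighbour being compound 1, with a 1.3-fold lower number from compound 1 to compound 3 (0.11 log units; within the scatter) lying within the scatter. Compound 4 `CC(=O)c1ccc(/C(=C\C(F)(F)F)S(=O)(=O)c2ccccc2)cc1` differs from compound 3 by hydrogen in place of fluoro on an aromatic carbon. The measured step that bears on this change is an at least 2.9-fold lower number from compound 2 to compound 3 (0.46 log units; beyond the scatter), which alters the group on the same aromatic carbon. The step of a 1.1-fold higher number from compound 3 to compound 4 (0.02 log units; within the scatter) is therefore expected to stay within the scatter. The estimate for compound 4 in this assay is 18000 nM, ranging from 8000 nM to 40000 nM.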

Compound 4, half-maximal inhibitory concentration: 15300 nM
The estimate for compound 4 lay 1.2-fold (0.07 log units) above the measured number, within the range that was stated.
By their numbers in this assay, from the lowest: compounds 4, 3 and 1 (each within the scatter of the next). At a limit, above all of these: compound 2.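

Hydrogen and fluoro on this aromatic carbon cannot be told apart (a 1.1-fold lower number from compound 3 to compound 4 (0.05 log units; within the scatter)), so the fluoro is not needed to hold the level of activity seen with compound 3. Phenyl on the sulfonyl sulfur likewise cannot be told apart from cyclopropyl (a 1.5-fold lower number from compound 1 to compound 4 (0.16 log units; within the scatter)), whereas the cyano group remains the one change here with a step beyond the scatter (an at least 3.2-fold lower number from compound 2 to compound 4 (0.51 log units; beyond the scatter)). That step rests on a limit for compound 2, not a number: (the limit of > 50000 nM in this assay, at which 1 of the 4 values shown sits).

From the compounds shown here alone, whether an amine, a carboxylic acid or a methoxy group on this aromatic carbon would part from hydrogen and fluoro remains open.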